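The compounds below may be only part of what the source reports. "The series", "measured", "known", "first", "only" and "open" are said of these compounds alone.

Compound 1 `O=S(=O)(CC1=NCCO1)C1C(c2ccc(Cl)cc2)=NOC1c1ccc(Cl)cc1` is reported in a functional assay, tested at 75 ug/mL (a higher number here means a stronger effect of the compound at the concentration tested, a lower number a weaker effect), as "not active" (no number reported), so no single number stands for it; compound 2 `O=S(=O)(CC1=NCCS1)c1c(-c2ccc(Cl)cc2)noc1-c1ccc(Cl)cc1` is likewise reported as "not active" (no number reported). Only compound 3 `O=S(=O)(CC1=NCCO1)c1c(-c2ccccc2)nn(-c2ccccc2)c1-c1ccccc1`, built on another core, gives a number: in this assay compound 3 reaches 57.3%. Compound 4 `O=S(=O)(CC1=NCCS1)C1C(c2ccc(Cl)cc2)=NOC1c1ccc(Cl)cc1` has not yet been measured. It differs from compound 1 by a group of 5 heavy atoms (3 carbon, 1 nitrogen, 1 sulfur; one five-membered non-aromatic ring with 2 hetero atoms) in place of a group of 5 heavy atoms (3 carbon, 1 nitrogen, 1 oxygen; one five-membered non-aromatic ring with 2 hetero atoms), on a saturated chain carbon bound to a sulfonyl sulfur. Among the compounds with values here, no step between measured compounds is known, so the size of this change in this assay cannot be read from any pair; with compound 1 and compound 2 both left without a single number, no rise beyond the scatter is expected, and the most likely outcome is again an entry without a number. Compound 4 is estimated at 8%, with a range from 0% to 30%.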

Compound 4, a percentage reported as activity, at one concentration (the size of the read-out at that concentration, not a potency): "not active" (no number reported)
The entry for compound 4 holds no number; there is nothing to compare the estimate with.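

Compound 1 and compound 4 are both entries without a number in this assay, so no step can be read between them, and nothing on hand bears on this result. The compounds shown leave open whether any compound on the core of compound 1 gives a numerical read-out.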